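The compounds below may be only part of what the source reports. "The series", "measured", "known", "first", "only" and "open" are said of these compounds alone.

Measured in a functional assay on PC-3 cells (Homo sapiens) for antiproliferative activity, read by MTT assay, with a stated time of 48 h; on this read-out higher numbers stand for weaker inhibition and lower numbers for stronger inhibition:
compound 1 `Cc1c(C(=O)c2ccccc2)oc2ccc(NS(=O)(=O)c3ccc(F)cc3)cc12` gives 38200 nM
compound 2 `Cc1c(C(=O)c2ccccc2)oc2ccc(NC(=O)c3ccc(F)cc3)cc12` gives 13500 nM

Compound 1 stands at the higher of the two numbers in this assay, the weaker inhibition of the pair; compound 2 sits at a lower number, a gap beyond the usual scatter. Compound 1 and compound 2 share the benzoyl group on the core and differ elsewhere, so neither gives a reference for the change now at hand.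

Compound 3 `CCOC(=O)c1oc2ccc(NS(=O)(=O)c3ccc(F)cc3)cc2c1C` keeps the sulfonamide side of compound 1 and changes the carbonyl substituent: ethoxy in place of phenyl on a carbonyl carbon. Among the compounds with values here, no measured pair shows this step, so its size is unknown. The working expectation is a small step toward weaker inhibition, or none beyond the scatter, since compound 1 already lies at a high number in this assay. The estimated step of a 1.4-fold higher number from compound 1 to compound 3 (0.16 log units; within the scatter) rests on that view. For compound 3 the expected value in this assay is 55000 nM, with a range from 18000 nM to 170000 nM, and a fair chance that only a limit is reported.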

Compound 3, half-maximal inhibitory concentration: 15900 nM
For compound 3 the middle estimate is 3.5-fold (0.54 log units) above the measured one; the whole stated range lies above it.
By their numbers in this assay, from the lowest: compounds 2 and 3 (each within the scatter of the next); then compound 1.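

Ethoxy in place of phenyl on a carbonyl carbon gives a 2.4-fold lower number from compound 1 to compound 3 (0.38 log units; beyond the scatter) in this assay and so shows that this position responds to its substituent, with the change running toward stronger inhibition. A phenyl ring on this carbonyl is therefore not needed to hold the activity of the sulfonamide compound, since ethoxycarbonyl, which carries no ring, reads better than benzoyl in this one pair, although the step is modest.

On these data alone, whether the same change would act alike on the amide of compound 2 remains open. Also open, as far as these compounds go, is how a carboxylic acid, a primary amine-bearing chain or a longer alkoxy chain on the same carbonyl carbon would read.

No measurement at hand accounts for this step.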